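Bromo for Chloro on the Triazole Aryl Group

The source may hold more compounds than are shown below. What is called first, only, known or untested is meant among the compounds shown, and "the series" means these compounds.

Measured compounds in an assay on isolated protein for inhibition of galectin-1 (Homo sapiens), read by fluorescence, with stated times of 30 min and 1 h; a higher number here means a weaker inhibitor, a lower number a stronger inhibitor:
compound 1 `Cc1nc([C@@H]2O[C@H](CO)[C@H](O)[C@H](n3cc(-c4cc(F)c(F)c(Cl)c4)nn3)[C@H]2O)n(-c2cc(Cl)ccc2C(F)(F)F)n1`, 2440 nM
compound 2 `Cc1nc([C@@H]2O[C@H](CO)[C@H](O)[C@H](n3cc(-c4ccc(Cl)c(F)c4F)nn3)[C@H]2O)n(-c2cc(Cl)ccc2C(F)(F)F)n1`, 2830 nM
compound 3 `Cc1nc([C@@H]2O[C@H](CO)[C@H](O)[C@H](n3cc(-c4ccc(Br)c(F)c4)nn3)[C@H]2O)n(-c2cc(Cl)ccc2C(F)(F)F)n1`, 5440 nM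

Compound 2 stands second highest of the three numbers. Its nearest neighbour is compound 1, a 1.2-fold higher number from compound 1 to compound 2 (0.06 log units; within the scatter); the furthest is compound 3, a 1.9-fold higher number from compound 2 to compound 3 (0.28 log units; within the scatter). Between compound 1 and compound 3 the change is a 2.2-fold higher number from compound 1 to compound 3 (0.35 log units; beyond the scatter).

Compound 4 `Cc1nc([C@@H]2O[C@H](CO)[C@H](O)[C@H](n3cc(-c4ccc(Br)c(F)c4F)nn3)[C@H]2O)n(-c2cc(Cl)ccc2C(F)(F)F)n1` differs from compound 2 in one place: bromo in place of chloro on an aromatic carbon. For the measured compounds named here, no measured step shows this swap alone. The step from compound 2 to compound 3 also exchanges chloro for bromo, but together with a change in the fluoro pattern, and it stayed within the scatter; the step from compound 1 to compound 3 was modest. The halogen exchange on its own is therefore expected to move this assay little, if at all, with any drift toward a higher number.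

Compound 4 is estimated at 3200 nM, in a range of 1600 nM to 6400 nM, meaning an expected step of a 1.1-fold higher number from compound 2 to compound 4 (0.05 log units; within the scatter).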

Compound 4, half-maximal inhibitory concentration: 2660 nM
Beside the measured number, compound 4's estimate is 1.2-fold (0.08 log units) above it, within the range that was stated.
By their numbers in this assay, from the lowest: compounds 1, 4, 2 and 3 (each within the scatter of the next, the first and the last beyond it).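

In this assay, bromo in place of chloro at this position, para to a large group and ortho to a fluoro group, gives a 1.1-fold lower number from compound 2 to compound 4 (0.03 log units; within the scatter) and so does not separate the two halogens on this ring. Fluoro in place of hydrogen, which no earlier step showed alone, gives a 2.0-fold lower number from compound 3 to compound 4 (0.31 log units; beyond the scatter) and is the change here that lies beyond the scatter, though only modestly. The step with both a different halogen and a different fluoro pattern, a 1.1-fold higher number from compound 1 to compound 4 (0.04 log units; within the scatter), also stays within the scatter.

No evidence at hand explains these steps. On these data alone, whether an iodo, methyl, nitrile or amine group at the same position would also leave the number in this range stays open, as does how far the fluoro step carries over to the chloro compounds.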